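Swapping Trifluoromethyl for (Cyclopropylamino)methyl on the Aryl Ring

A few compounds are considered here, and "the series" means these few. Any claim that something is new, unique, unknown or untested is made for them only; others in the source may bear on it.

Compound 1 `Cn1nc2c(=O)n(CC3(O)CCN(Cc4ccc(-c5ccco5)cc4Cl)CC3)cnc2c1-c1ccc(C(N)=O)cc1` gives 80.8 nM in an assay on isolated protein for inhibition of ubiquitin carboxyl-terminal hydrolase 7 (Homo sapiens), with stated times of 30 min and 2 h; a lower number here means a stronger inhibitor, a higher number a weaker inhibitor.
Compound 2 `Cn1nc2c(=O)n(CC3(O)CCN(Cc4ccc(-c5ccco5)cc4Cl)CC3)cnc2c1-c1ccc(C(F)(F)F)cc1` gives 530 nM in this assay.
Compound 3 `Cn1nc2c(=O)n(CC3(O)CCN(Cc4ccc(-c5cccs5)cc4Cl)CC3)cnc2c1-c1ccc(CN)cc1` gives 38.6 nM in this assay.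

Among these three, compound 2 has the highest number, so it is the weakest inhibitor shown; compound 1 sits nearest to it, and compound 3 furthest, both with lower numbers beyond the scatter. The step to the unmeasured compound 4 `Cn1nc2c(=O)n(CC3(O)CCN(Cc4ccc(-c5ccco5)cc4Cl)CC3)cnc2c1-c1ccc(CNC2CC2)cc1` is (cyclopropylamino)methyl in place of trifluoromethyl on an aromatic carbon. Among the measured compounds shown here, only one measured step touches the same position: a 6.6-fold higher number from compound 1 to compound 2 (0.82 log units; beyond the scatter), where a trifluoromethyl in place of a carbamoyl raised the number. Going the other way, from trifluoromethyl to a group that again carries a hydrogen-bond donor and acceptor, should therefore lower the number. Compound 3, which carries an aminomethyl at that position together with a thiophene rather than a furan, shows a lower number still. On that basis compound 4 is expected to improve on compound 2 by about an 8.8-fold lower number from compound 2 to compound 4 (0.95 log units; beyond the scatter), and its value in this assay is estimated at 60 nM, within a range of 20 nM to 200 nM.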

Compound 4, half-maximal inhibitory concentration: 54.1 nM
Compound 4: middle estimate off by 1.1-fold (0.04 log units), on the high side; the measured number falls inside the stated range.
By their numbers in this assay, from the lowest: compounds 3, 4 and 1 (each within the scatter of the next, the first and the last beyond it); then compound 2.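

In this assay, (cyclopropylamino)methyl in place of trifluoromethyl gives a 9.8-fold lower number from compound 2 to compound 4 (0.99 log units; beyond the scatter), so a second group carrying a hydrogen-bond donor and acceptor, and this time a three-membered ring, is also far better than trifluoromethyl on this aromatic carbon. Against carbamoyl, the change gives a 1.5-fold lower number from compound 1 to compound 4 (0.17 log units; within the scatter), so these two different groups cannot be told apart in this assay, and the added ring brings no measurable loss or gain. No measured evidence explains either result.

The compounds shown do not separate the part played by the nitrogen from that of the cyclopropyl ring, since compound 3 also differs from compound 4 in its thiophene. A hydroxymethyl or a dimethylaminomethyl group on the same aromatic carbon would address that question.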